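The compounds below may be only part of what the source reports. "The series", "measured", "known", "first", "only" and "open" are said of these compounds alone.

Measured so far in a functional assay on CHO cells with adenosine receptor A1 (Homo sapiens) as the target, read by cAMP accumulation and immunoassay, with a stated time of 6 min, tested at 10 uM; a lower number here means a stronger effect, a higher number a weaker effect of the compound at the concentration tested:
compound 1, `Nc1scc(CN2CCN(c3cc(Cl)cc(Cl)c3)CC2)c1C(=O)c1ccc(Cl)cc1`, gives -74%
compound 2, `Nc1scc(CN2CCN(c3ccc(Cl)c(C(F)(F)F)c3)CC2)c1C(=O)c1ccc(Cl)cc1`, gives -60%
compound 3, `Nc1scc(CN2CCN(c3cccc(F)c3)CC2)c1C(=O)c1ccc(Cl)cc1`, gives -82%

Compound 3 stands lowest of the three numbers in this assay. Its nearest neighbour is compound 1, reached by a number 8 percentage points lower from compound 1 to compound 3 (within the scatter); its furthest is compound 2, reached by a number 22 percentage points lower from compound 2 to compound 3 (beyond the scatter). The remaining measured step, a number 14 percentage points higher from compound 1 to compound 2 (beyond the scatter), likewise only exchanges the aromatic group on the ring nitrogen.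

Compound 4, `Nc1scc(CN2CCN(c3ccccc3Cl)CC2)c1C(=O)c1ccc(Cl)cc1`, is not yet measured. It differs from compound 3 in one place: 2-chlorophenyl in place of 3-fluorophenyl on an amine nitrogen in a ring. Among the compounds with values here, no measured step exchanges 3-fluorophenyl for 2-chlorophenyl, so none bears directly on this change; what the three steps do show is that exchanging one aromatic group on that ring nitrogen for another moves the number in this assay either within the scatter or by a modest amount, and in both directions. Compound 3 already sits lowest of the three, so a modest rise rather than a further fall is the more likely outcome for compound 4. For compound 4 the expected step is a number 12 percentage points higher from compound 3 to compound 4 (beyond the scatter). Compound 4 is therefore estimated at -70%, within a range from -88% to -50%.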

Compound 4, a percentage reported as activity, at one concentration (the size of the read-out at that concentration, not a potency): -18%
The estimate for compound 4 lay 52 percentage points below the measured number, outside the stated range (above it).
By their numbers in this assay, from the lowest: compounds 3 and 1 (each within the scatter of the next); then compound 2; then compound 4.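

In this assay, within the data shown here, exchanging one aromatic group for another on the amine nitrogen in a ring had so far moved the number by no more than a modest amount, but 2-chlorophenyl brings a much larger change: a number 64 percentage points higher from compound 3 to compound 4 (beyond the scatter), a number 56 percentage points higher from compound 1 to compound 4 (beyond the scatter) and a number 42 percentage points higher from compound 2 to compound 4 (beyond the scatter), each step large. This position is therefore far less forgiving than the first three compounds suggested, and the change from 3-fluorophenyl to 2-chlorophenyl produces this shift although the two groups match in heavy-atom count, have no hydrogen-bond donors or acceptors and carry no net charge. Nothing available explains why this group weakens the effect so sharply.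

The compounds shown do not separate the identity of the halogen from its place on the phenyl ring, a question that 2-fluorophenyl and 3-chlorophenyl would help to settle. They also leave open whether the loss is particular to chlorine or extends to other groups in the same place on the ring, such as the methyl of 2-methylphenyl or the methoxy of 2-methoxyphenyl.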